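The source may report more compounds than this note shows. Statements on the series, on what has been measured and on what is new or still open speak of the compounds shown alone.

The study looks at four amides built on two related cores and tested in an ADME assay on HEK293 cells (Homo sapiens) for cytotoxicity, read by MTT assay, with a stated time of 48 h; on this read-out higher numbers stand for weaker inhibition and lower numbers for stronger inhibition. Compound 1, `CCS(=O)(=O)Nc1ccc(NC(=O)c2cccc(C(F)(F)F)c2)cc1C`, gives 210000 nM in this assay. Compound 2, `CCS(=O)(=O)Nc1ccc(NC(=O)c2cc(C(F)(F)F)cc(C(F)(F)F)c2)cc1C`, carries a second trifluoromethyl and gives 126000 nM. The change between them, (trifluoromethyl in place of hydrogen on an aromatic carbon), produced a 1.7-fold lower number from compound 1 to compound 2 (0.22 log units; within the scatter), so the two values are not distinguished by this read-out.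

Compound 3, `COc1cc(NC(=O)c2cccc(C(F)(F)F)c2)ccc1NS(C)(=O)=O`, is built on the other core; how that core differs from the core of compound 1 is not broken down here. In this assay compound 3 reaches only a limit of the assay, > 250000 nM. This is the situation described by the limit of > 250000 nM in this assay, at which 1 of the 3 values shown sits, and it leaves the starting point for the next step without a fixed number.

Compound 4, `COc1cc(NC(=O)c2cc(C(F)(F)F)cc(C(F)(F)F)c2)ccc1NS(C)(=O)=O`, has not yet been measured. Within the data shown here, it differs from compound 3 by trifluoromethyl in place of hydrogen on an aromatic carbon, which is the same kind of change as the one from compound 1 to compound 2, and the surroundings of the new group are described in the same words in both cases. Given that the earlier step was within the scatter, compound 4 is expected to sit near the limit reached by compound 3. The expected step in this assay is estimated as an at least 1.2-fold lower number from compound 3 to compound 4 (0.09 log units; that floor lies within the scatter). For compound 4 the estimated value is 200000 nM, with a range from 100000 nM to 400000 nM, and a fair chance remains that the assay reports only a limit for it.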

Compound 4, half-maximal inhibitory concentration: 42000 nM
Estimate against measurement, compound 4: 4.8-fold (0.68 log units) above, and the stated range ends above it.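

In this assay, the same trifluoromethyl change gave an at least 5.9-fold lower number from compound 3 to compound 4 (0.77 log units; beyond the scatter), and this step does not match the one seen on the core of compound 1, so its size did not carry over from one core to the other: the same change on two cores in this assay, a 1.7-fold lower number (0.22 log units; within the scatter) from compound 1 to compound 2 and an at least 5.9-fold lower number (0.77 log units; beyond the scatter) from compound 3 to compound 4, at least 3.5-fold (0.55 log units) apart, beyond the scatter of two such steps

Compound 3 gives only a limit of the assay, > 250000 nM, and not a number: the limit of > 250000 nM in this assay, at which 1 of the 4 values shown sits.

The step to compound 4 is therefore known only as a floor, and with a single pair on each core the result does not show which of the differences between the two cores goes with the gap, nor whether a third core would follow either pair.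

The compounds shown leave open whether a group other than trifluoromethyl at the same place, such as a nitrile, a chlorine atom or a carboxylic acid, would give steps that also differ between the two cores. They also leave open how the two cores compare when only one feature is exchanged at a time, for example the ethyl of the sulfonamide for a methyl with everything else kept the same.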